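Methyl added on the ether chain: outlook for compound 4

The source may hold more compounds than are shown below. What is called first, only, known or untested is meant among the compounds shown, and "the series" means these compounds.

Measured compounds, all in a functional assay on CHO cells with sphingosine 1-phosphate receptor 4 (Homo sapiens) as the target, read by GTPgammaS binding; on this read-out higher numbers stand for an effect only at larger amounts of compound and lower numbers for an effect already at smaller amounts:
Compound 1 `CCOc1ccc(-c2nc(-c3ccc(CCC(=O)O)cc3C)no2)cc1C(F)(F)F` gives > 10000 nM; this is a limit of the assay, not a number.
Compound 2 `COc1ccc(-c2nc(-c3ccc(CCC(=O)O)cc3C)no2)cc1C(F)(F)F` gives > 10000 nM; again a limit.
Compound 3 `Cc1cc(CCC(=O)O)ccc1-c1noc(-c2ccc(OC(C)C)c(C#N)c2)n1` gives > 10000 nM; again a limit.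

Compound 1 and compound 2 differ by methyl in place of hydrogen on a saturated chain carbon bound to an oxygen on an aromatic ring. The step that the two limits leave unreadable from compound 2 to compound 1 cannot be sized, as both values sit at the limit, (the limit of > 10000 nM in this assay, at which 3 of the 3 values shown sit). How the core of compound 3 differs from that of compound 2 is not broken down here.

Compound 4 `CC[C@H](C)Oc1ccc(-c2nc(-c3ccc(CCC(=O)O)cc3C)no2)cc1C#N` is not yet measured. It differs from compound 3 by methyl in place of hydrogen on a saturated chain carbon, two bonds along the chain from an oxygen on an aromatic ring. This is the same kind of change as that from compound 2 to compound 1, but the place is not identical: there the carbon is bound to the oxygen on the aromatic ring, here it lies two bonds along the chain from that oxygen.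

With all three measured values at the limit, the expected step from compound 3 to compound 4 is estimated as a step that the limit leaves unreadable from compound 3 to compound 4, resting on compound 3 giving > 10000 nM and on the unreadable step between compound 2 and compound 1. Compound 4 is expected to give about 15000 nM, most likely again only a limit.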

Compound 4, half-maximal effective concentration: > 10000 nM
Compound 4: only a limit was reported; the forecaster's own chance of this, stated with the estimate: 75%; the middle value does not contradict the limit.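

No step can be read from compound 3 to compound 4, and the change from isopropoxy to sec-butoxy cannot be sized, as both compounds sit at the limit: the limit of > 10000 nM in this assay, at which 4 of the 4 values shown sit.

The compounds shown leave open whether any change in the ether chain alters the effect on this receptor, as none of them gives a number rather than a limit.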